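The compounds below may be only part of what the source reports. "The series", "measured", "known", "first", "only" and "open" are said of these compounds alone.

Compound 1 `CNc1nccc(N2CC[C@H](NC(=O)Nc3ccc(CN(C)C)c(C(F)(F)F)c3)C2)n1` gives 102000 nM in a physicochemical assay for solubility, measured as kinetic solubility; a lower number here means a less soluble compound, a higher number a more soluble compound

Compound 2 `O=C(Nc1ccc(Cl)c(C(F)(F)F)c1)N[C@@H]1CCN(c2ccc3nncn3n2)C1` gives 1000 nM in this assay

Compound 1 holds the highest of these two numbers, and compound 2 lies beyond the scatter below it. The two compounds do not differ in just one place, so their gap says little about any single group. Compound 3 `CCN1CCN(Cc2ccc(NC(=O)N[C@H]3CCN(c4ccnc(NC)n4)C3)cc2C(F)(F)F)CC1` has not yet been measured. It keeps the core of compound 1 and changes one group: 4-ethylpiperazin-1-yl in place of dimethylamino on a saturated chain carbon bound to an aromatic carbon in short, 4-ethylpiperazin-1-yl in place of dimethylamino on a saturated chain carbon bound to an aromatic carbon. For the measured compounds named here, no measured pair shows this change, so the data offer no direct guide. The expectation in this assay is therefore no step beyond the scatter, with a slight lean towards a lower number. The expected size is a 1.3-fold lower number from compound 1 to compound 3 (0.11 log units; within the scatter) as estimated here. For compound 3 the expected value is 80000 nM with an estimated range from 30000 nM to 160000 nM for now.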

Compound 3, solubility: 132000 nM
Compound 3: middle estimate off by 1.7-fold (0.22 log units), on the low side; measured number inside the range.
By their numbers in this assay, from the lowest: compound 2; then compounds 1 and 3 (each within the scatter of the next).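

A step of a 1.3-fold higher number from compound 1 to compound 3 (0.11 log units; within the scatter) in this assay shows that 4-ethylpiperazin-1-yl can stand in place of dimethylamino on a saturated chain carbon bound to an aromatic carbon without a readable shift in the number. At this place on the core of compound 1, a group of 8 heavy atoms with a six-membered non-aromatic ring therefore reads the same as a group of 3 heavy atoms with no ring. Nothing measured here explains this outcome.

The compounds shown leave open whether the number would also hold with a morpholin-4-yl group or a carboxylic acid at this place. They also leave open whether the same swap reads alike on a different core, since compound 2 differs from compound 1 in more than one place.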